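Compound 2 to compound 3: a change at the limit

This account rests on a few compounds, and the source may have more. Where it says the series, first, only, none or still open, it means among the compounds named here.

In a functional assay on MCF7 cells (Homo sapiens) for inhibition (a lower number here means a stronger inhibitor of growth, a higher number a weaker inhibitor of growth), compound 1 (`O=C(Oc1ccccc1)c1ccsc1NC(=O)[C@@H]1CCCN1`) gives > 250 ug/mL as a limit of the assay. Compound 2 (`O=C(OCC(Cl)(Cl)Cl)c1ccsc1NC(=O)[C@@H]1CCCN1`) gives > 250 ug/mL and this is also a limit, so compound 2 has no numerical value. The record so far reads the limit of > 250 ug/mL in this assay, at which 2 of the 2 values shown sit, and holds no number.

Compound 3 (`O=C1CC[C@@H](COC(=O)c2ccsc2NC(=O)[C@@H]2CCCN2)N1`) differs from compound 2 by 5-oxopyrrolidin-2-yl in place of trichloromethyl on a saturated chain carbon bound to an oxygen next to a carbonyl group and this amounts to 5-oxopyrrolidin-2-yl in place of trichloromethyl on a saturated chain carbon bound to an oxygen next to a carbonyl group.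

Within the data shown here, the only measured step is a step that the two limits leave unreadable from compound 1 to compound 2 and it replaced phenyl with 2,2,2-trichloroethyl on an oxygen next to a carbonyl group. It gives no size to carry forward. Among the measured compounds shown here, no step beyond the scatter is expected in this assay because a step that the two limits leave unreadable from compound 1 to compound 2 is the only precedent, and no direction can be read from it. The expected step is a number no higher from compound 2 to compound 3 (the limit leaves the size open) on this weak footing. For compound 3 the estimate is 250 ug/mL with an expected range from 120 ug/mL to 500 ug/mL and a report of only a limit is the likeliest outcome.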

Compound 3, concentration for 50% growth inhibition: 148 ug/mL
The estimate for compound 3 lay 1.7-fold (0.23 log units) above the measured number, within the range that was stated.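

In this assay, among these compounds, compound 3 is the only one of the three compounds that reads as a number rather than a limit, so a change on a saturated chain carbon bound to an oxygen next to a carbonyl group can bring the read-out within the measurable range: 5-oxopyrrolidin-2-yl in place of trichloromethyl gives an at least 1.6-fold lower number from compound 2 to compound 3 (0.22 log units; that floor lies within the scatter). Set against phenyl, the same end of the molecule gives an at least 1.6-fold lower number from compound 1 to compound 3 (0.22 log units; that floor lies within the scatter), and as both steps are floors, their true sizes remain open and neither can be called a real gain in growth inhibition on the printed figures. The step between the other two compounds cannot be read, and the record still rests largely on a single limit: the limit of > 250 ug/mL in this assay, at which 2 of the 3 values shown sit.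

The compounds shown leave open whether the step belongs to the ring, the carbonyl or the hydrogen-bond donor of 5-oxopyrrolidin-2-yl, and whether the opposite stereocentre would read the same. A pyrrolidin-2-yl group without the carbonyl, an open-chain amide or a carboxylic acid at the same place would begin to separate these parts.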